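Pancreatic cell growth inhibition by aryl-substituted bis(trifluoromethyl)benzenesulfonamides

This account rests on a few compounds, and the source may have more. Where it says the series, first, only, none or still open, it means among the compounds named here.

Measured compounds:
compound 1, `O=S(=O)(NCCCNCc1ccccc1Cl)c1cc(C(F)(F)F)cc(C(F)(F)F)c1`: 13000 nM
compound 2, `O=S(=O)(NCCNCc1ccc(-c2ccccc2)cc1)c1cc(C(F)(F)F)cc(C(F)(F)F)c1`: 2800 nM
compound 3, `COc1ccc(CNCCCNS(=O)(=O)c2cc(C(F)(F)F)cc(C(F)(F)F)c2)cc1OC`: 6400 nM

In a functional assay on ASPC1 cells (Homo sapiens) for inhibition, read by MTT assay, with a stated time of 72 h (on this read-out higher numbers stand for weaker inhibition of growth and lower numbers for stronger inhibition of growth), compound 1 gives the highest of the three numbers; compound 3 comes nearest, and compound 2, which differs from compound 1 in both the chain and the aryl group, gives the lowest number of the set. Compound 4, `O=S(=O)(NCCCNCc1ccc(Cl)c(C(F)(F)F)c1)c1cc(C(F)(F)F)cc(C(F)(F)F)c1`, keeps the chain and sulfonamide of compound 1 and differs only in the aryl group: 4-chloro-3-(trifluoromethyl)phenyl in place of 2-chlorophenyl on a saturated chain carbon bound to an amine nitrogen.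

Among the compounds with values here, the one step that bears directly on this change is a 2.0-fold lower number from compound 1 to compound 3 (0.31 log units; beyond the scatter), which swapped the same 2-chlorophenyl for another aryl group at the same place and moved the number by a modest, measurable amount. No aryl group of this kind has been measured here, so the direction is taken from that single step. A step of similar size, downward, is therefore expected for compound 4 in this assay, about a 2.0-fold lower number from compound 1 to compound 4 (0.30 log units; within the scatter). Compound 4 is estimated at 6500 nM, with a range of 2500 nM to 17000 nM.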

Compound 4, concentration for 50% growth inhibition: 9600 nM
Beside the measured number, compound 4's estimate is 1.5-fold (0.17 log units) below it; measured number inside the range.
By their numbers in this assay, from the lowest: compound 2; then compounds 3, 4 and 1 (each within the scatter of the next, the first and the last beyond it).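

In this assay the swap gives a 1.4-fold lower number from compound 1 to compound 4 (0.13 log units; within the scatter) and so stays within the scatter, even though 4-chloro-3-(trifluoromethyl)phenyl brings 11 heavy atoms where 2-chlorophenyl has 7. Within the data shown here, the same group also cannot be told apart from 3,4-dimethoxyphenyl, with a 1.5-fold higher number from compound 3 to compound 4 (0.18 log units; within the scatter) lying within the scatter, and this leaves a 2.0-fold lower number from compound 1 to compound 3 (0.31 log units; beyond the scatter) as the only step at this place that goes beyond it. No measurement is available to explain why these aryl changes move the number so little.

The compounds shown do not separate the effect of the chain from that of the aryl group in compound 2, which differs from the others in both places. They also leave open whether a longer chain, or an amine or carboxylic acid on the aryl ring, would move the number beyond the scatter.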